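A Pyridine Nitrogen Shift on the Shared Core

The source may report more compounds than this note shows. Statements on the series, on what has been measured and on what is new or still open speak of the compounds shown alone.

Three esters of one shared core have been examined in a functional assay on HL-60 cells (Homo sapiens) for cytotoxicity, read by MTT assay, with a stated time of 48 h; a lower number here means a stronger inhibitor, a higher number a weaker inhibitor. Compound 1 `COc1ccc(OC(=O)c2cn(-c3ccccc3)nc2-c2cccnc2)cc1` reaches only the limit of that assay, giving > 100000 nM. Going by the values given here, compound 2 `Cc1ccc(C(C)C)c(OC(=O)c2cn(-c3ccccc3)nc2-c2cccnc2)c1` gives 22700 nM, the only actual number obtained so far, so it stands alone as the reference point. Compound 3 `O=C(Oc1ccc2ccccc2c1)c1cn(-c2ccccc2)nc1-c1cccnc1` is recorded as "nd(insoluble)" (no result reported), and no value exists for it. Among the compounds with values here, the single measured step, an at least 4.4-fold lower number from compound 1 to compound 2 (0.64 log units; beyond the scatter), exchanges the group on an oxygen next to a carbonyl group; because compound 1 sits at the limit named in the limit of > 100000 nM in this assay, at which 1 of the 3 values shown sits, the true size of that step is not fixed.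

Compound 4 `Cc1ccc(C(C)C)c(OC(=O)c2cn(-c3ccccc3)nc2-c2ccncc2)c1` differs from compound 2 by pyridin-4-yl in place of pyridin-3-yl on an aromatic carbon. Within the data shown here, no measured step touches this part of the molecule: the one available step concerns the group on the oxygen next to the carbonyl and says nothing about the pyridyl ring. With no guidance from the data, the step of no change at the digits printed from compound 2 to compound 4 (within the scatter) is expected to stay within the usual scatter, with an equal chance of a small move in either direction. The estimate for compound 4 in this assay is accordingly 22700 nM, expected to fall between 7000 nM and 70000 nM.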

Compound 4, half-maximal inhibitory concentration: 17800 nM
Estimate against measurement, compound 4: 1.3-fold (0.11 log units) above; low and high end bracket the measured number.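

In this assay, the exchange of pyridin-3-yl for pyridin-4-yl gives a 1.3-fold lower number from compound 2 to compound 4 (0.11 log units; within the scatter), so the two pyridyl rings cannot be told apart at this position. Going by these compounds alone, the only earlier step concerned the group on the oxygen next to the carbonyl, whereas this pair gives the first reading on the aromatic carbon that carries the pyridyl ring, and with the 2-isopropyl-5-methylphenyl group held fixed, joining the same ring atoms differently produces no difference beyond the scatter. None of the data shown bears on why compound 2 and compound 4 read so closely.

The compounds shown leave open whether a pyridin-2-yl ring, a plain phenyl ring or a pyridyl ring carrying an amine or a carboxylic acid would read the same at this position. On these data alone, it is also open whether this lack of difference extends to other groups on the oxygen or to an amide in place of the ester, as the comparison rests on a single pair sharing one ester group.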